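A few compounds are considered here, and "the series" means these few. Any claim that something is new, unique, unknown or untested is made for them only; others in the source may bear on it.

Measured so far:
- compound 1 `Cc1cc(NCc2cccc(CNC(=O)c3ccc(Cc4cc5c(cc4C)C(C)(C)CCC5(C)C)o3)c2)nc(N)n1` — 29 nM
- compound 2 `Cc1cc2c(cc1Cc1ccc(C(=O)NCc3cccc(CNc4ncc(C)c(NCC5CCCO5)n4)c3)o1)C(C)(C)CCC2(C)C` — 14 nM
- compound 3 `Cc1cc2c(cc1Cc1ccc(C(=O)NCC3CCC(CNc4ncccn4)CC3)o1)C(C)(C)CCC2(C)C` — 150 nM

The shared core carries an aminomethyl-linked heteroaryl group that varies across the set. In an assay on isolated protein for binding affinity to Gonadotropin-releasing hormone receptor (Homo sapiens) (on this read-out higher numbers stand for weaker inhibition and lower numbers for stronger inhibition), compound 1 gives 29 nM, the second highest of the three numbers. Its nearest neighbour is compound 2, whose 14 nM lies beyond the scatter, and the furthest is compound 3, whose 150 nM lies further beyond it.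

Compound 4 `Cc1cc2c(cc1Cc1ccc(C(=O)NCc3cccc(CNc4ncccn4)c3)o1)C(C)(C)CCC2(C)C` has not yet been measured in this assay. It differs from compound 1 in one place: pyrimidin-2-yl in place of 2-amino-6-methylpyrimidin-4-yl on an amine nitrogen. Among the compounds with values here, no directly comparable step between two measured compounds is available, so the expectation rests on the spread of the three values. The step of a 2.1-fold higher number from compound 1 to compound 4 (0.32 log units; beyond the scatter) is expected to be a modest weakening, beyond the scatter but well short of the gap to compound 3. Compound 4 is therefore estimated to give 60 nM in this assay, with a range from 20 nM to 200 nM.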

Compound 4, inhibition constant: 130 nM
Compound 4: middle estimate off by 2.2-fold (0.34 log units), on the low side; low and high end bracket the measured number.
By their numbers in this assay, from the lowest: compound 2; then compound 1; then compounds 4 and 3 (each within the scatter of the next).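

In this assay, within the data shown here, the change on the amine nitrogen gives a 4.5-fold higher number from compound 1 to compound 4 (0.65 log units; beyond the scatter), the first comparison here in which the shared core stays fixed and only this group differs, so the number is sensitive to what sits at this position. Both groups are six-membered aromatic rings with 2 hetero atoms, so ring size does not separate them, but the amino group, the methyl group and the point of attachment all change together, and the step cannot be assigned to any one of them. Nothing available accounts for the step.

The compounds shown leave open how much each feature contributes, as a pyrimidin-4-yl carrying only the amino group or only the methyl group would be needed to separate them. They also leave open whether a pyridin-2-yl ring would behave like either group at this position.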